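The compounds below may be only part of what the source reports. "The series", "measured", "known", "first", "only" and "open" are said of these compounds alone.

Compound 1, with the structure `CC(C)=CC[C@@H](OC(=O)c1ccoc1)C1=CC(=O)c2c(O)ccc(O)c2C1=O`, carries a furan-3-yl ester on the shared core. In a functional assay on DU-145 cells (Homo sapiens) for cytotoxicity, read by MTT assay (on this read-out higher numbers stand for weaker inhibition and lower numbers for stronger inhibition), compound 1 gives only > 100000 nM, which is a limit of the assay rather than a measured number. So on the numbers shown, compound 1 stands at the limit of > 100000 nM in this assay, at which 1 of the 2 values shown sits, and its true position is not pinned down. Compound 2, with the structure `CCC(C)(O)CC(=O)O[C@H](CC=C(C)C)C1=CC(=O)c2c(O)ccc(O)c2C1=O`, replaces that ester with a 2-hydroxy-2-methylbutyl ester; in this assay compound 2 gives 16000 nM. The step is an at least 6.2-fold lower number from compound 1 to compound 2 (0.79 log units; beyond the scatter).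

Compound 3 has the structure `CCCC(CC(=O)O[C@H](CC=C(C)C)C1=CC(=O)c2c(O)ccc(O)c2C1=O)OC(C)=O`. Against compound 1 the change is 2-acetoxypentyl in place of furan-3-yl on a carbonyl carbon. Within the data shown here, only the single step from compound 1 to compound 2 bears on this: it also swaps the furan-3-yl ester for an open-chain ester, and it lowered the number by at least a modest amount. The same direction is expected here, as a step of an at least 5.0-fold lower number from compound 1 to compound 3 (0.69 log units; beyond the scatter). Compound 3 is therefore estimated at 20000 nM in this assay, within a range from 5000 nM to 80000 nM.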

Compound 3, half-maximal inhibitory concentration: 55700 nM
Beside the measured number, compound 3's estimate is 2.8-fold (0.44 log units) below it; the measured number falls inside the stated range.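

Moving from one open-chain ester to another matters at this position in this assay, as the replacement of 1-hydroxy-1-methylpropyl by 1-acetoxybutyl gives a 3.5-fold higher number from compound 2 to compound 3 (0.54 log units; beyond the scatter). An open chain in place of furan-3-yl is therefore not enough to fix the number, and what the chain carries counts as well. Against the furan-3-yl ester, the 2-acetoxypentyl ester gives an at least 1.7-fold lower number from compound 1 to compound 3 (0.25 log units; that floor lies within the scatter), so a real gain can be claimed for compound 2 but not for compound 3, and compound 1 remains a limit of the assay: the limit of > 100000 nM in this assay, at which 1 of the 3 values shown sits.

The step from compound 2 to compound 3 changes the hydroxy group to an acetoxy group and alters the shape of the chain at the same time, so the compounds shown cannot say which of these changes accounts for the higher number. A 1-hydroxybutyl chain would separate the two changes, while an amine in place of the hydroxy group or a longer chain would test how far this position reaches beyond the groups shown here.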